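Removing the chloro from the benzoyl ring of compound 2

The source may report more compounds than this note shows. Statements on the series, on what has been measured and on what is new or still open speak of the compounds shown alone.

Compound 2 `O=C(Nc1ccccc1O)C1CCc2ccccc2N1C(=O)c1ccc(Cl)cc1` shows the highest number of the three compounds in a functional assay on HCT-15 cells (Homo sapiens) for cytotoxicity, read by sulforhodamine B assay, with a stated time of 72 h; on this read-out higher numbers stand for weaker inhibition of growth and lower numbers for stronger inhibition of growth: compound 2 gives 20200 nM, while compound 1 `O=C(Nc1cc(C(F)(F)F)cc(C(F)(F)F)c1)C1CCc2ccccc2N1C(=O)c1ccccc1Cl` gives 4050 nM and compound 3 `O=C(Nc1ccccc1C(F)(F)F)C1CCc2ccccc2N1C(=O)c1ccc(Cl)cc1` gives 839 nM. Among the measured compounds shown here, the only single-change step measured, a 24-fold lower number from compound 2 to compound 3 (1.38 log units; beyond the scatter), concerns the amide-bearing ring, not the benzoyl ring. Compound 4 `O=C(Nc1ccccc1O)C1CCc2ccccc2N1C(=O)c1ccccc1` differs from compound 2 by hydrogen in place of chloro on an aromatic carbon. For the measured compounds named here, no measured step touches this position, so the expectation rests only on the size of changes seen elsewhere and the usual scatter. A small or no step beyond the scatter is expected, and compound 4 is estimated at 25000 nM, with a range of 8000 nM to 80000 nM, the step of a 1.2-fold higher number from compound 2 to compound 4 (0.09 log units; within the scatter) being expected only tentatively.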

Compound 4, concentration for 50% growth inhibition: 3830 nM
For compound 4 the middle estimate is 6.5-fold (0.81 log units) above the measured one; measured number outside the range, below it.
By their numbers in this assay, from the lowest: compound 3; then compounds 4 and 1 (each within the scatter of the next); then compound 2.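

Among the compounds shown here, the step of a 5.3-fold lower number from compound 2 to compound 4 (0.72 log units; beyond the scatter) shows that this position matters, which none of the earlier compounds could show, as they offered no step here. With the hydroxy-bearing amide ring held fixed, going from 4-chlorophenyl to phenyl gives stronger inhibition of growth, so here the chloro is a drawback rather than a neutral passenger. Still open, as far as these compounds go, is whether losing the chloro would help equally in the trifluoromethyl-bearing compound 3, and what a methoxy group or an amine in this place would do. No measurement at hand explains this step.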